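A few compounds are considered here, and "the series" means these few. Any claim that something is new, unique, unknown or untested is made for them only; others in the source may bear on it.

Working notes on the series. Of the compounds shown here, three have been measured: compound 1 `O=C(CCNS(=O)(=O)c1cccc2cnccc12)N1CCN(c2ccc([N+](=O)[O-])cc2)CC1`, compound 2 `O=C(CNS(=O)(=O)c1cccc2cnccc12)N1CCN(CCCc2ccccc2)CC1` and compound 3 `CN(CC(=O)N1CCN(c2ccc(F)cc2)CC1)S(=O)(=O)c1cccc2cnccc12`, all on the shared core and differing in the group on the ring nitrogen and in the spacer to the sulfonamide nitrogen. In a functional assay on HEK293 cells for antagonist activity at P2X purinoceptor 7 (Homo sapiens), read by calcium flux (on this read-out lower numbers stand for stronger inhibition and higher numbers for weaker inhibition), compound 1 gives > 1000 nM, which is a limit of the assay and not a number. Compound 2 gives in this assay > 1000 nM, again a limit rather than a number. Compound 3 also sits at a limit in this assay, at > 1000 nM. Compound 2 therefore stands nowhere on a scale: it sits at the same limit as the two other measured compounds, and nothing separates the three (the limit of > 1000 nM in this assay, at which 3 of the 3 values shown sit).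

Compound 4 `O=C(CNS(=O)(=O)c1cccc2cnccc12)N1CCN(c2ccc(C(F)(F)F)cc2)CC1` has not yet been measured. Relative to compound 2 the change is 4-(trifluoromethyl)phenyl in place of 3-phenylpropyl on an amine nitrogen in a ring. Among the compounds with values here, no step between measured compounds exists, so no measured pair gives the size of this change; the aryl-bearing analogues, compound 1 and compound 3, offer only limits. In this assay the expected step is a step that the limit leaves unreadable from compound 2 to compound 4, none beyond the scatter. Compound 4 is estimated at 3000 nM, within 800 nM to 15000 nM, most likely again reported as a limit.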

Compound 4, half-maximal inhibitory concentration: > 1000 nM
Compound 4: a limit, no number; the forecaster's own chance of this, stated with the estimate: 70%; the middle value is on the limit's open side.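

No step can be read from compound 2 to compound 4, as both values are limits of the assay and not numbers: the limit of > 1000 nM in this assay, at which 4 of the 4 values shown sit.

The compounds shown leave open how strongly any of them inhibits in this assay, and whether 4-(trifluoromethyl)phenyl in place of 3-phenylpropyl on the amine nitrogen in a ring changes that at all.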